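The source may report more compounds than this note shows. Statements on the series, on what has been measured and on what is new or still open speak of the compounds shown alone.

In a functional assay on MCF7 cells (Homo sapiens) for cytotoxicity, read by MTT assay, with a stated time of 72 h (a higher number here means a weaker inhibitor, a lower number a stronger inhibitor), compound 1 `COc1ccc2nc(-c3ccc(-n4c(C)ccc4-c4ccc(C)cc4)cc3)sc2c1` gives 2850 nM. Compound 2 `COc1ccc2nc(-c3ccc(-n4c(C)ccc4-c4ccc(F)cc4)cc3)sc2c1` differs from compound 1 by fluoro in place of methyl on an aromatic carbon and in this assay compound 2 gives 2800 nM, so that change produced a 1.0-fold lower number from compound 1 to compound 2 (0.01 log units; within the scatter). Compound 3 `COc1cc2nc(-c3ccc(-n4c(C)ccc4-c4ccc(C)cc4)cc3)sc2c(OC)c1OC` carries a different core; the difference between the two cores is not broken down here. In this assay compound 3 gives 3110 nM, a number close to those of compound 1 and compound 2. Compound 4 `COc1cc2nc(-c3ccc(-n4c(C)ccc4-c4ccc(F)cc4)cc3)sc2c(OC)c1OC` is compound 3 with the same change, (fluoro in place of methyl on an aromatic carbon), at a place described in the same words as for compound 1 and compound 2. The step from compound 3 to compound 4 is expected to be a 1.0-fold lower number from compound 3 to compound 4 (0.02 log units; within the scatter), because the same change gave a 1.0-fold lower number from compound 1 to compound 2 (0.01 log units; within the scatter). Compound 4 is therefore estimated at 3000 nM, expected to fall between 1500 nM and 6000 nM.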

Compound 4, half-maximal inhibitory concentration: 2910 nM
Estimate against measurement, compound 4: 1.0-fold (0.01 log units) above; low and high end bracket the measured number.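

In this assay, the swap of methyl for fluoro gave a 1.1-fold lower number from compound 3 to compound 4 (0.03 log units; within the scatter), and the two steps agree: the same change on two cores in this assay, a 1.0-fold lower number (0.01 log units; within the scatter) from compound 1 to compound 2 and a 1.1-fold lower number (0.03 log units; within the scatter) from compound 3 to compound 4, 1.0-fold (0.02 log units) apart, within the scatter of two such steps. On these two cores, then, the change from 4-methylphenyl to 4-fluorophenyl carried over as a step that cannot be told from the scatter. Within the data shown here, this shows only that the change left the number in place on both cores; two such flat steps do not show that a change with a real effect would carry over in the same way, nor do they say anything about other cores.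

The compounds shown leave open whether another group at that place, such as an amine, a carboxylic acid or a methoxy group, would move the number at all. They also leave open whether any group there can bring the number clearly away from those of compound 1 to compound 4.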